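The compounds below may be only part of what the source reports. "The series", "measured", "known", "first", "only" and "open" are said of these compounds alone.

Three compounds have been measured in an assay on membranes from HEK293 cells for displacement of a labelled ligand from adenosine receptor A2b (Homo sapiens), read by scintillation counting, with a stated time of 30 min, tested at 1 uM; a higher number here means more inhibition at the concentration tested (going by the name of the read-out), a lower number less inhibition:

Compound 1, `CC(=O)C1=C(C)NC(=O)NC1c1ccoc1`, gives 15%.
Compound 2, `CC1=C(C(=O)C2CC2)C(c2ccoc2)NC(=O)N1`, gives 10%.
Compound 3, `CC1=C(C(=O)NC(C)C)C(c2ccoc2)NC(=O)N1`, gives 3%.

Compound 3 holds the lowest of the three numbers. Its distance from compound 1 is a number 12 percentage points lower from compound 1 to compound 3 (beyond the scatter), which lies beyond the scatter, whereas its distance from compound 2 is a number 7 percentage points lower from compound 2 to compound 3 (within the scatter), which does not, so compound 3 and compound 2 cannot be told apart on these numbers. The step from compound 1 to compound 2, a number 5 percentage points lower from compound 1 to compound 2 (within the scatter), is likewise within the scatter.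

Compound 4 is `CCSC(=O)C1=C(C)NC(=O)NC1c1ccoc1`. It differs from compound 3 in one place: ethylsulfanyl in place of isopropylamino on a carbonyl carbon. The two steps that bear on this change are the ones in which isopropylamino entered on the carbonyl carbon: from compound 1, a number 12 percentage points lower from compound 1 to compound 3 (beyond the scatter), and from compound 2, a number 7 percentage points lower from compound 2 to compound 3 (within the scatter). Both moved the number downward, one beyond the scatter and one within it. Going by the values given here, compound 4 undoes the isopropylamino, but replaces it with ethylsulfanyl, for which no measured step exists. The expectation in this assay is therefore a modest rise of about a number 6 percentage points higher from compound 3 to compound 4 (within the scatter), which could still fall within the scatter. For compound 4 the estimate is 9%, with a range from 0% to 20%.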

Compound 4, a percentage reported as inhibition, at one concentration (the size of the read-out at that concentration, not a potency): 1%
Estimate against measurement, compound 4: 8 percentage points above, within the range that was stated.
By their numbers in this assay, from the lowest: compounds 4, 3, 2 and 1 (each within the scatter of the next, the first and the last beyond it).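

In this assay, ethylsulfanyl on the carbonyl carbon cannot be told apart from isopropylamino (a number 2 percentage points lower from compound 3 to compound 4 (within the scatter)) or from cyclopropyl (a number 9 percentage points lower from compound 2 to compound 4 (within the scatter)), so exchanging the nitrogen-linked group with its hydrogen-bond donor for a sulfur-linked group without one produces no readable change at this position. Measured against methyl (a number 14 percentage points lower from compound 1 to compound 4 (beyond the scatter)), ethylsulfanyl becomes the second group at this carbonyl carbon, after isopropylamino (a number 12 percentage points lower from compound 1 to compound 3 (beyond the scatter)), whose step lies beyond the scatter, while cyclopropyl (a number 5 percentage points lower from compound 1 to compound 2 (within the scatter)) goes against any such reading for all replacements of methyl because its step stays within it.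

The compounds shown leave open whether an ethoxy group, which would complete the comparison of nitrogen, sulfur and oxygen on the carbonyl carbon, would read any differently from ethylsulfanyl, and whether a longer chain on the sulfur would move the number at all. They also leave open whether a free carboxylic acid or an unsubstituted amide at this carbonyl carbon would rise above methyl in compound 1 (15%), the highest number among these four compounds.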